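A few compounds are considered here, and "the series" means these few. Any claim that something is new, unique, unknown or untested is made for them only; others in the source may bear on it.

Measured compounds in the series:

Compound 1 `CCn1c(C(=O)NCCNC(=O)OC(C)(C)C)ccc1C(CC)(CC)c1ccc(OCS(=O)(=O)c2ccccc2)c(C)c1` – in a functional assay on MCF7 cells (Homo sapiens) for antiproliferative activity, read by MTT assay, with a stated time of 24 h (on this read-out higher numbers stand for weaker inhibition and lower numbers for stronger inhibition), compound 1 reaches only the assay limit, > 50000 nM, and gives no number.
Compound 2 `CCn1c(C(=O)N[C@@H](CO)C(C)C)ccc1C(CC)(CC)c1ccc(OCS(=O)(=O)c2ccccc2)c(C)c1` – in this assay compound 2 gives 18800 nM.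
Compound 3 `CCn1c(C(=O)N[C@H](CO)CCO)ccc1C(CC)(CC)c1ccc(OCS(=O)(=O)c2ccccc2)c(C)c1` – in this assay compound 3 gives 28500 nM.

Compound 3 holds the higher of the two measured numbers, yet its separation from compound 2 is within the scatter: a 1.5-fold higher number from compound 2 to compound 3 (0.18 log units; within the scatter). Against the limit of compound 1 the same holds, since an at least 1.7-fold lower number from compound 1 to compound 3 (0.24 log units; that floor lies within the scatter), whereas an at least 2.6-fold lower number from compound 1 to compound 2 (0.42 log units; beyond the scatter).

Compound 4 `CCn1c(C(=O)N[C@@H](CC(=O)O)C(=O)O)ccc1C(CC)(CC)c1ccc(OCS(=O)(=O)c2ccccc2)c(C)c1` has not been measured. Relative to compound 3 the change is 1,2-dicarboxyethyl in place of 3-hydroxy-1-(hydroxymethyl)propyl on an amide-type nitrogen. Going by the values given here, no measured step exchanges one such group for another like it; the three measured steps all sit on the same amide-type nitrogen, and the only one beyond the scatter, an at least 2.6-fold lower number from compound 1 to compound 2 (0.42 log units; beyond the scatter), concerns the limit of compound 1 (the limit of > 50000 nM in this assay, at which 1 of the 3 values shown sits). The measured numbers span a narrow band, so the step in this assay is expected to be small and more likely towards a higher number, with a fair chance that compound 4 returns only a limit.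

For compound 4 the estimate in this assay is 40000 nM, between 12000 nM and 150000 nM, which is expected to mean a 1.4-fold higher number from compound 3 to compound 4 (0.15 log units; within the scatter).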

Compound 4, half-maximal inhibitory concentration: > 50000 nM
Compound 4: only a limit was reported (the forecaster's own chance of this, stated with the estimate: 40%); middle value at least 1.2-fold (0.09 log units) from the limit.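

Compound 4, with 1,2-dicarboxyethyl on the amide-type nitrogen, returns only a limit in this assay, the second such result at this position: the limit of > 50000 nM in this assay, at which 2 of the 4 values shown sit.

Replacing 1-(hydroxymethyl)-2-methylpropyl with 1,2-dicarboxyethyl gives an at least 2.6-fold higher number from compound 2 to compound 4 (0.42 log units; beyond the scatter), whereas replacing 3-hydroxy-1-(hydroxymethyl)propyl gives an at least 1.7-fold higher number from compound 3 to compound 4 (0.24 log units; that floor lies within the scatter), so only the first exchange is shown to exceed the scatter. The step between the two limits cannot be read, and among the compounds shown, actual numbers occur only with the two hydroxyl-bearing groups.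

Going by these compounds, it remains open whether a single carboxylic acid, a free amine or a longer hydroxyalkyl chain on this nitrogen would give a number in this assay. The true positions of the two limit compounds relative to each other also remain unresolved.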